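This account rests on a few compounds, and the source may have more. Where it says the series, first, only, none or still open, it means among the compounds named here.

Measured so far: compound 1, `Cc1cc(F)ccc1C1=Nc2c(Cl)cccc2SC(C(=O)O)C1`, in a functional assay on LoVo cells (Homo sapiens), read by MTT assay, with a stated time of 72 h (on this read-out lower numbers stand for stronger inhibition of growth and higher numbers for weaker inhibition of growth), gives 16800000 nM. Compound 2, `Cc1cc(F)ccc1C1=Nc2c(Br)cccc2SC(C(=O)O)C1`, in this assay gives > 20000000 nM, which is a limit of the assay rather than a number.

For the measured compounds named here, compound 2 therefore stands at the limit of > 20000000 nM in this assay, at which 1 of the 2 values shown sits; the only measured step toward it, an at least 1.1-fold higher number from compound 1 to compound 2 (0.07 log units; that floor lies within the scatter), is bromo in place of chloro and carries a floor that lies within the scatter. Compound 3, `Cc1cc(F)ccc1C1=Nc2c(F)cccc2SC(C(=O)O)C1`, differs from compound 2 by fluoro in place of bromo on an aromatic carbon. Going by the values given here, the one step that bears on this change, from chloro to bromo, showed nothing beyond the scatter, so a halogen exchange at this aromatic carbon gives no reason to expect a step beyond the scatter in this assay in either direction; the weak inhibition of growth seen for compound 1 is the best anchor. Compound 3 is accordingly expected to give about 18000000 nM in this assay, estimated to fall between 8000000 nM and 45000000 nM. The expected step is an at least 1.1-fold lower number from compound 2 to compound 3 (0.04 log units; that floor lies within the scatter).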

Compound 3, concentration for 50% growth inhibition: 3800000 nM
For compound 3 the middle estimate is 4.7-fold (0.68 log units) above the measured one, outside the stated range (below it).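

At this aromatic carbon the choice of halogen does change the result in this assay: fluoro in place of chloro gives a 4.4-fold lower number from compound 1 to compound 3 (0.65 log units; beyond the scatter), and fluoro in place of bromo gives an at least 5.2-fold lower number from compound 2 to compound 3 (0.72 log units; beyond the scatter). For the compounds shown here, the earlier exchange of chloro for bromo showed only a floor within the scatter, so fluoro is the first group here to separate from the others, with stronger inhibition of growth than either heavier halogen. Compound 2 still stands at a limit of the assay and not at a number, so its step to the fluoro compound is only a floor: the limit of > 20000000 nM in this assay, at which 1 of the 3 values shown sits.

The compounds shown leave open whether the stronger inhibition of growth is particular to fluoro or would also appear with a non-halogen group at this aromatic carbon, such as a methoxy group or an amine. They also leave open how an amide in place of the carboxylic acid would read out alongside the fluoro group.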